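This account rests on a few compounds, and the source may have more. Where it says the series, first, only, none or still open, it means among the compounds named here.

Measured so far:
- Compound 1 `CC(C)Oc1cc(Oc2ccc(S(C)(=O)=O)cc2)cc(-c2nccc(=O)[nH]2)c1`: < 9.8 mL/min/kg
- Compound 2 `Cc1cnc(-c2cc(Oc3ccc(S(C)(=O)=O)cc3)cc(OC(C)C)c2)[nH]c1=O`: < 8 mL/min/kg

In an ADME assay on microsomes from liver (Homo sapiens) for metabolic stability (on this read-out higher numbers stand for fast clearance and lower numbers for slow clearance), compound 2 stands at < 8 mL/min/kg, which is a limit and not a number. Compound 1 also has only a limit, < 9.8 mL/min/kg.

Compound 3 `CCc1cnc(-c2cc(Oc3ccc(S(C)(=O)=O)cc3)cc(OC(C)C)c2)[nH]c1=O` extends compound 2 by one carbon: methyl in place of hydrogen on a saturated chain carbon bound to an aromatic carbon. This places methyl in place of hydrogen on a saturated chain carbon bound to an aromatic carbon, turning methyl into ethyl.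

Going by the values given here, one measured step bears on this change: a step that the two limits leave unreadable from compound 1 to compound 2. It also adds a methyl in place of hydrogen, though on an aromatic carbon. Both of its ends are limits, so it gives no size to carry over. With no measured size to go on, the expected a number no lower from compound 2 to compound 3 (the limit leaves the size open) is no change beyond the usual scatter. For compound 3, the estimated clearance is 8 mL/min/kg, with an expected range from 4 mL/min/kg to 16 mL/min/kg.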

Compound 3, clearance: < 8 mL/min/kg
Compound 3 ended at the assay's limit (the forecaster's own chance of this, stated with the estimate: 60%); the middle value sits exactly at the limit.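

The steps among compound 1, compound 2 and compound 3 cannot be read in this assay: each of the three results is a limit of the assay, not a number. The compounds shown leave open what their true clearances are, and whether adding methyl or ethyl changes clearance at all.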